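Five-membered aryl replacements on a nucleoside core

The source may hold more compounds than are shown below. What is called first, only, known or untested is meant among the compounds shown, and "the series" means these compounds.

Measured compounds:
compound 1 `O=c1[nH]cnc2c1c(-c1ccoc1)cn2[C@@H]1O[C@H](CO)[C@@H](O)[C@H]1O` — 12500 nM
compound 2 `O=c1[nH]cnc2c1c(-c1ccsc1)cn2[C@@H]1O[C@H](CO)[C@@H](O)[C@H]1O` — > 20000 nM
compound 3 `C#Cc1cn([C@@H]2O[C@H](CO)[C@@H](O)[C@H]2O)c2nc(C)nc(N)c12` — > 20000 nM

The read-out is a functional assay on K562 cells (Homo sapiens), read by MTT assay, with a stated time of 72 h; on this read-out higher numbers stand for weaker inhibition and lower numbers for stronger inhibition. Compound 1 gives 12500 nM in this assay. For compound 2 this assay reports only a limit, > 20000 nM. For compound 3 this assay likewise reports only a limit, > 20000 nM. Compound 2 therefore stands at the weak end of what has been resolved, and no number is known for it; compound 3 shares that position.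

For the measured compounds named here, the only step measured is an at least 1.6-fold higher number from compound 1 to compound 2 (0.20 log units; that floor lies within the scatter); its size is bounded by the limit of > 20000 nM in this assay, at which 2 of the 3 values shown sit, and is not settled beyond the scatter. Compound 3 shares no single-point relation with the others, so its value shows only that it, too, sits at the limit.

Compound 4 `O=c1[nH]cnc2c1c(-c1cc3ccccc3o1)cn2[C@@H]1O[C@H](CO)[C@@H](O)[C@H]1O` differs from compound 2 by 1-benzofuran-2-yl in place of thiophen-3-yl on an aromatic carbon. Going by the values given here, no measured step covers 1-benzofuran-2-yl, so the expectation rests on compound 2 starting at the limit and on an at least 1.6-fold higher number from compound 1 to compound 2 (0.20 log units; that floor lies within the scatter) being unresolved. Compound 4 is expected to give about 20000 nM, within 5000 nM to 60000 nM. The expected step is a number no higher from compound 2 to compound 4 (the limit leaves the size open), with a real chance that this assay again reports only a limit.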

Compound 4, half-maximal inhibitory concentration: > 20000 nM
Compound 4 was reported as a limit (the forecaster's own chance of this, stated with the estimate: 55%); the middle value lies on the limit itself.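

In this assay compound 4 is reported only as a limit, > 20000 nM, so a group with a six-membered aromatic ring added to the five-membered one, on the same aromatic carbon, also gives no resolved value. Against the single-ring furan-3-yl the change reads as an at least 1.6-fold higher number from compound 1 to compound 4 (0.20 log units; that floor lies within the scatter), so nothing here points to stronger inhibition with the larger 1-benzofuran-2-yl, while the step from compound 2 cannot be read, as both ends are limits. The new point is that the single-ring and two-ring replacements can no longer be told apart at this position, and the read-out itself now restricts what the series can show: the limit of > 20000 nM in this assay, at which 3 of the 4 values shown sit.

As far as these compounds go, how far compound 2 and compound 4 lie beyond the limit remains unknown, so no order can be given between thiophen-3-yl and 1-benzofuran-2-yl. Also open, from the compounds shown here alone, is whether a group of another kind on this aromatic carbon, such as an amine or a carboxylic acid, would bring the value into the resolved range.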